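A few compounds are considered here, and "the series" means these few. Any claim that something is new, unique, unknown or untested is made for them only; others in the source may bear on it.

For the measured compounds named here, compound 1 `CCOC(=O)c1ccc(/N=N/N(C)C(=O)[C@H](C)NC(C)=O)cc1` gives 4.6 h in an ADME assay on a cell-free system (plasma, Homo sapiens) for metabolic stability, read by HPLC (on this read-out lower numbers stand for a shorter-lived compound and higher numbers for a longer-lived compound), the highest of the three numbers measured so far. Compound 2 `CC(=O)NCC(=O)N(C)/N=N/c1ccc(C#N)cc1` gives 1.2 h in this assay, and compound 3 `CCCC(=O)N[C@@H](C)C(=O)N(C)/N=N/c1ccc(C#N)cc1` gives 1.1 h; both of these sit beyond the scatter below compound 1. Compound 4 `CC(=O)N[C@@H](C)C(=O)N(C)/N=N/c1ccc(C(C)=O)cc1` differs from compound 1 by methyl in place of ethoxy on a carbonyl carbon. Going by the values given here, no measured pair shows this particular step, so the expected size rests only on the spread seen among the three. The step from compound 1 is expected to be a modest one, downward, likely within the scatter, at a 1.5-fold lower number from compound 1 to compound 4 (0.19 log units; within the scatter). Compound 4 is therefore expected to give about 3 h, between 1.5 h and 6 h.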

Compound 4, half-life: 2.3 h
For compound 4 the middle estimate is 1.3-fold (0.12 log units) above the measured one; low and high end bracket the measured number.
By their numbers in this assay, from the lowest: compounds 3, 2, 4 and 1 (each within the scatter of the next, the first and the last beyond it).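

For the compounds shown here, putting methyl in place of ethoxy on a carbonyl carbon gives a 2.0-fold lower number from compound 1 to compound 4 (0.30 log units; within the scatter) in this assay, the first step in this set that changes a single place. At this position, then, ethoxycarbonyl to acetyl is a change that the half-life does not separate from the usual scatter. No measurement at hand bears on the reason for this result.

Going by these compounds, it remains open how a carboxylic acid or a longer chain in place of ethoxy on this carbonyl carbon would read. On these data alone, whether the same step holds on a different acylamino side chain also stays open.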